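The compounds below may be only part of what the source reports. "The series", "measured", "known", "first", "only" and "open" are said of these compounds alone.

Three compounds of the series share one core and differ only in the aryl group on the saturated chain carbon bound to an aromatic carbon. Compound 1 `O=C(NCCO)c1cccc2c1CCN2c1cc(Cc2cc(F)cc(C(F)(F)F)c2)ncn1` gives 136% in a functional assay on HEK293 cells for agonist activity at G-protein coupled receptor 52 (Homo sapiens), read by cAMP accumulation, with a stated time of 15 min; on this read-out lower numbers stand for smaller maximal responses and higher numbers for larger maximal responses. Compound 2 `O=C(NCCO)c1cccc2c1CCN2c1cc(Cc2cccc(C(F)(F)F)c2)ncn1` gives 127% in this assay, and compound 3 `O=C(NCCO)c1cccc2c1CCN2c1cc(Cc2ccc(C(F)(F)F)cc2)ncn1` gives 136% in this assay. The single-point steps are all small: a number 9 percentage points lower from compound 1 to compound 2 (within the scatter), no change at the digits printed from compound 1 to compound 3 (within the scatter) and a number 9 percentage points higher from compound 2 to compound 3 (within the scatter). Compound 3 is thus level with compound 1 at the digits reported, and its gap to compound 2 also stays within the scatter, so no order among the three can be read from these numbers.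

Compound 4 `Cc1cccc(Cc2cc(N3CCc4c(C(=O)NCCO)cccc43)ncn2)c1` is the next member. Its change from compound 3 is 3-methylphenyl in place of 4-(trifluoromethyl)phenyl on a saturated chain carbon bound to an aromatic carbon. The two measured steps that bear on it are the earlier aryl swaps at this same place, no change at the digits printed from compound 1 to compound 3 (within the scatter) and a number 9 percentage points higher from compound 2 to compound 3 (within the scatter), neither of which moved the maximal response beyond the scatter. A methyl-bearing aryl has not yet been measured, so the expectation rests on these swaps alone. On that basis the expected step is a number 6 percentage points lower from compound 3 to compound 4 (within the scatter), that is, none beyond the scatter. Compound 4 is therefore estimated at 130%, with a range from 110% to 150%.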

Compound 4, largest response reached (Emax), in percent of the reference or control that the assay uses: 144%
Compound 4: the middle estimate sits 14 percentage points below what was measured; the measured number falls inside the stated range.
By their numbers in this assay, from the lowest: compounds 2, 1, 3 and 4 (each within the scatter of the next, the first and the last beyond it).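

Methyl in place of trifluoromethyl on an aromatic carbon gives a number 17 percentage points higher from compound 2 to compound 4 (beyond the scatter) in this assay, the first single-place step in this set to pass the scatter. The other two new steps, a number 8 percentage points higher from compound 3 to compound 4 (within the scatter) and a number 8 percentage points higher from compound 1 to compound 4 (within the scatter), do not pass it, so compound 3 and compound 1 go against any general claim that 3-methylphenyl separates from the trifluoromethyl-bearing aryl groups, and the separation holds only against compound 2. Within the data shown here, this place on the saturated chain carbon thus accepts an aryl group carrying no fluorine while the maximal response stays within the scatter of compound 1 and compound 3, and no measurement of another property accompanies these steps to account for the single step beyond the scatter.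

Still open, going by these compounds, is whether methyl in place of trifluoromethyl gives a step of like size on the aryl group of compound 3, which would need 4-methylphenyl at this place. Also open, on these data alone, is how this place responds to other aryl substituents, such as a methoxy group, a chlorine atom, a nitrile or a dimethylamino group, or to a longer chain between the aryl ring and the shared core.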